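Piperidinyl to pyrrolidinyl on two fused cores

This account rests on a few compounds, and the source may have more. Where it says the series, first, only, none or still open, it means among the compounds named here.

Compound 1 `COc1ncc(-c2cc3c(N4CCCCC4)ncnc3s2)cc1NS(=O)(=O)c1ccc(F)cc1F` and compound 2 `COc1ncc(-c2cc3c(N4CCCC4)ncnc3s2)cc1NS(=O)(=O)c1ccc(F)cc1F` share one core; compound 3 `COc1ncc(-c2nc3c(N4CCCCC4)ncnc3s2)cc1NS(=O)(=O)c1ccc(F)cc1F` and compound 4 `COc1ncc(-c2nc3c(N4CCCC4)ncnc3s2)cc1NS(=O)(=O)c1ccc(F)cc1F` share another, and the difference between the two cores is not broken down here. In a functional assay on HGC-27 cells (Homo sapiens) for antiproliferative activity, read by MTT assay, with stated times of 72 h and 4 h (a lower number here means a stronger inhibitor, a higher number a weaker inhibitor), compound 1 gives 1200 nM, compound 2 gives 2300 nM and compound 3 gives 960 nM. The change from compound 1 to compound 2 is pyrrolidin-1-yl in place of piperidin-1-yl on an aromatic carbon, and in this assay it gave a 1.9-fold higher number from compound 1 to compound 2 (0.28 log units; within the scatter). The change from compound 3 to compound 4 is pyrrolidin-1-yl in place of piperidin-1-yl on an aromatic carbon, the same change at the same place on the other core. Compound 4 is not yet measured in this assay. Going by the values given here, the step expected is a 1.9-fold higher number from compound 3 to compound 4 (0.27 log units; within the scatter), resting on the single earlier instance a 1.9-fold higher number from compound 1 to compound 2 (0.28 log units; within the scatter), which is the only basis available. For compound 4 the estimated value in this assay is 1800 nM, expected between 900 nM and 3600 nM.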

Compound 4, half-maximal inhibitory concentration: 1200 nM
Estimate against measurement, compound 4: 1.5-fold (0.18 log units) above; measured number inside the range.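

On the second core in this assay, pyrrolidin-1-yl in place of piperidin-1-yl gave a 1.3-fold higher number from compound 3 to compound 4 (0.10 log units; within the scatter) and so repeats the earlier result, with no difference between the cores that these data can resolve: the same change on two cores in this assay, a 1.9-fold higher number (0.28 log units; within the scatter) from compound 1 to compound 2 and a 1.3-fold higher number (0.10 log units; within the scatter) from compound 3 to compound 4, 1.5-fold (0.19 log units) apart, within the scatter of two such steps

As both steps lie within the scatter, neither core shows a real effect of this change, and no direction can be assigned to it. Two pairs do not establish that the change would behave the same way on any core beyond those of compounds 1 to 4.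

The compounds shown leave open how a morpholine or an open-chain dimethylamine would behave at this aromatic carbon. They also leave open whether either would move the number beyond the scatter on either core.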